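Amino in place of dimethylamino on the shared core

The source may hold more compounds than are shown below. What is called first, only, known or untested is meant among the compounds shown, and "the series" means these compounds.

Three compounds carry numbers in a functional assay (Homo sapiens) for inhibition of Nucleic Acid, tested at 100 uM; on this read-out higher numbers stand for more inhibition at the one concentration tested (going by the name of the read-out) and lower numbers for less inhibition. Compound 1 `CSc1nccc2c1ncn2[C@H]1C[C@H](O)[C@@H](CO)O1` gives 36%, compound 2 `OC[C@H]1OC(n2cnc3c(SCc4ccccc4)nccc32)[C@H](O)[C@@H]1O` gives 30%, and compound 3 `CN(C)c1[nH]ccc2ncnc1-2` gives 8%. Compound 3 stands lowest of the three: compound 2 is its nearest neighbour, higher by a gap beyond the scatter, and compound 1 lies furthest off, also beyond the scatter. Within the data shown here, no pair among the three differs in one place, so no measured step guides the next change. Compound 4 `Nc1[nH]ccc2ncnc1-2` differs from compound 3 as follows: amino in place of dimethylamino on an aromatic carbon. Among the measured compounds shown here, with no comparable step on record, the expected change in this assay is a number 4 percentage points higher from compound 3 to compound 4 (within the scatter), small and without a clear direction beyond the scatter. Compound 4 is accordingly estimated at 12%, within 0% to 30%.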

Compound 4, a percentage reported as inhibition, at one concentration (the size of the read-out at that concentration, not a potency): 60%
Beside the measured number, compound 4's estimate is 48 percentage points below it; the whole stated range lies below it.
By their numbers in this assay, from the lowest: compound 3; then compounds 2 and 1 (each within the scatter of the next); then compound 4.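

In this assay, among these compounds, the swap to amino on this aromatic carbon, next to the ring nitrogen, gives a number 52 percentage points higher from compound 3 to compound 4 (beyond the scatter) as the first single-place step. The position is therefore sensitive to its substituent: with the shared core unchanged, this one group accounts for the whole difference. Nothing on hand explains the size of the step.

Open, as far as these compounds go, is whether methylamino would fall between the two compounds or follow either one. Also open, from the compounds shown here alone, is how a hydroxyl or a longer chain on the nitrogen would read at this position.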